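Replacing methoxycarbonyl with methyl on compound 1

A few compounds are considered here, and "the series" means these few. Any claim that something is new, unique, unknown or untested is made for them only; others in the source may bear on it.

Compound 1 `COC(=O)c1ccc(-n2cc(CCCOS(=O)(=O)c3ccc(C)cc3)nn2)cc1` gives > 100000 nM (a limit, not a number)
Compound 2 `COC(=O)c1ccc(-n2cc(CCCOS(=O)(=O)c3ccc(-c4ccccc4)cc3)nn2)cc1` gives 26000 nM (a measured number)

On these data alone, in a functional assay on HepG2 cells (Homo sapiens) for cytotoxicity, read by MTT assay, with a stated time of 72 h (a lower number here means a stronger inhibitor, a higher number a weaker inhibitor), compound 1 has only a limit and no exact number (the limit of > 100000 nM in this assay, at which 1 of the 2 values shown sits) so its true position is unknown. The next compound to be tested is compound 3 `Cc1ccc(-n2cc(CCCOS(=O)(=O)c3ccc(C)cc3)nn2)cc1` and it carries methyl in place of methoxycarbonyl on an aromatic carbon while the rest of compound 1 stays the same.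

For the measured compounds named here, only one measured step starts from compound 1. It is an at least 3.8-fold lower number from compound 1 to compound 2 (0.58 log units; beyond the scatter) and it came with phenyl in place of methyl on an aromatic carbon. That step changed a different part of the molecule and put a larger group in, whereas this change puts a smaller group in. It therefore offers only a loose guide, and no large move towards a lower number is expected. A small step or none beyond the scatter seems most likely, and compound 3 may again give only a limit. The estimated change is an at least 1.2-fold lower number from compound 1 to compound 3 (0.09 log units; that floor lies within the scatter) as the expected step here. Compound 3 is estimated at 80000 nM with an expected range from 30000 nM to 200000 nM in this assay as the likely outcome.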

Compound 3, half-maximal inhibitory concentration: 100000 nM
Compound 3: the middle estimate sits 1.3-fold (0.10 log units) below what was measured; measured number inside the range.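

In this assay compound 3, which carries methyl in place of methoxycarbonyl on an aromatic carbon para to a large group, gives 100000 nM, a measured number, so this position now has an exact value with the small group in place. Compound 1 gives only a limit, > 100000 nM. The change from methoxycarbonyl to methyl gave a number no higher from compound 1 to compound 3 (the limit leaves the size open), but the size of this step cannot be read, because one end of the comparison is only a limit: the limit of > 100000 nM in this assay, at which 1 of the 3 values shown sits.

For the compounds shown here, whether any other group at this position would move the number clearly remains open, for example an amine, a carboxylic acid or a chlorine atom, since methoxycarbonyl and methyl are the only two groups compared here. Also open, on these data alone, is whether the phenyl group that sets compound 2 apart from compound 1 would be followed by a similar step in this assay when methyl rather than methoxycarbonyl sits at this position.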